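The source may hold more compounds than are shown below. What is called first, only, known or untested is meant among the compounds shown, and "the series" means these compounds.

Measured compounds:
compound 1 `CC(C)(C)NC(=O)N1CC1C#N`, 418000 nM
compound 2 `CCOC(=O)c1ccc(NC(=O)N2CC2C#N)cc1`, 5800 nM

In a functional assay on A-375 cells (Homo sapiens) for inhibition (on this read-out lower numbers stand for stronger inhibition and higher numbers for weaker inhibition), compound 2 gives the lower of the two numbers, and compound 1 gives a number that lies far higher, beyond the scatter. The unmeasured compound 3 `N#CC1CN1C(=O)Nc1ccccc1` differs from compound 2 by hydrogen in place of ethoxycarbonyl on an aromatic carbon. Among the compounds with values here, with no comparable step among the measured pair, the size of this change can only be estimated. Compound 3 is expected to retain the aromatic urea and to lose ground, and for compound 3 the expected step is a 5.2-fold higher number from compound 2 to compound 3 (0.71 log units; beyond the scatter). Compound 3 is therefore expected to give about 30000 nM, within a range from 8000 nM to 120000 nM.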

Compound 3, half-maximal inhibitory concentration: 11000 nM
Estimate against measurement, compound 3: 2.7-fold (0.44 log units) above; measured number inside the range.
By their numbers in this assay, from the lowest: compounds 2 and 3 (each within the scatter of the next); then compound 1.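

In this assay, hydrogen in place of ethoxycarbonyl on the aromatic carbon gives a 1.9-fold higher number from compound 2 to compound 3 (0.28 log units; within the scatter). At this position, the five heavy atoms of the ethoxycarbonyl can therefore be lost without a difference that stands out from the scatter, and compound 3 keeps a value comparable to that of compound 2. Nothing available accounts for this result. Going by these compounds, it remains open how an amine or a carboxylic acid at this position would read out in this assay, and whether other places on the aromatic ring tolerate change equally.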